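The source may hold more compounds than are shown below. What is called first, only, known or untested is meant among the compounds shown, and "the series" means these compounds.

Measured compounds:
Compound 1, `CCC(=O)N1CC2CC(C1)N2`: 180 nM
Compound 2, `CC(C)C(=O)N1CC2CC(C1)N2`: 16000 nM
Compound 3, `O=C([C@H]1C[C@H]1F)N1CC2CC(C1)N2`: 62 nM

In an assay on CHO cells for agonist activity at Neuronal acetylcholine receptor; alpha3/alpha6/beta2/beta3 (Homo sapiens), read by FLIPR and calcium flux (on this read-out higher numbers stand for an effect only at larger amounts of compound and lower numbers for an effect already at smaller amounts), compound 3 holds the lowest number of the three. Its nearest neighbour is compound 1, with a 2.9-fold lower number from compound 1 to compound 3 (0.46 log units; beyond the scatter); the furthest is compound 2, with a 260-fold lower number from compound 2 to compound 3 (2.41 log units; beyond the scatter). Compound 4, `O=C([C@@H]1C[C@H]1F)N1CC2CC(C1)N2`, keeps every atom and bond of compound 3; the only difference is the two compounds have the same atoms and bonds; at least one stereo element is drawn with a configuration in one of them and without one in the other: 1 of 4 stereo elements differ; a stereocentre at a saturated ring carbon is drawn R in compound 3 and S in compound 4. Going by the values given here, none of the measured steps touches a stereocentre: the steps of an 89-fold higher number from compound 1 to compound 2 (1.95 log units; beyond the scatter) and a 2.9-fold lower number from compound 1 to compound 3 (0.46 log units; beyond the scatter) swap one acyl group for another, and so they show only how much the acyl part as a whole can matter, not how two spatial arrangements of the same fluorocyclopropyl group compare. Among the compounds with values here, the expectation for compound 4 therefore rests on no direct precedent and must be wide. Compound 4 is expected to give 150 nM in this assay, within a range of 30 nM to 800 nM. That estimate means an expected step of a 2.4-fold higher number from compound 3 to compound 4 (0.38 log units; beyond the scatter), modest and toward a higher number, but a result on either side of compound 3 would not be surprising.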

Compound 4, half-maximal effective concentration: 53 nM
Compound 4: the middle estimate sits 2.8-fold (0.45 log units) above what was measured, and the stated range covers the measured number.
By their numbers in this assay, from the lowest: compounds 4 and 3 (each within the scatter of the next); then compound 1; then compound 2.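

In this assay, going by these compounds alone, the stereocentre at a saturated ring carbon, drawn R in compound 3 and S in compound 4, gives a 1.2-fold lower number from compound 3 to compound 4 (0.07 log units; within the scatter), so the two compounds cannot be told apart at this position, whereas the earlier steps showed only swaps of one acyl group for another. The standing of the 2-fluorocyclopropyl group holds in this second drawn form as well, with a 3.4-fold lower number from compound 1 to compound 4 (0.53 log units; beyond the scatter) against the ethyl compound and a 300-fold lower number from compound 2 to compound 4 (2.48 log units; beyond the scatter) against the isopropyl compound. One caution applies to reading the pair as two defined arrangements: the fact that one of compounds 3 and 4 is drawn with a defined configuration and the other without, at the place where they differ.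

The compounds shown leave open how the remaining stereocentres of the 2-fluorocyclopropyl group bear on the read-out. They also leave open whether the fluorine matters at all, since a plain cyclopropyl or a 2,2-difluorocyclopropyl group is not among them.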